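Compound 2 to compound 3: acetyl replaces methyl

This account rests on a few compounds, and the source may have more. Where it says the series, first, only, none or still open, it means among the compounds named here.

Measured in a physicochemical assay for solubility, read by spectrophotometry, measured as kinetic solubility, at pH 8, tested at 500 uM; a lower number here means a less soluble compound, a higher number a more soluble compound:
- Compound 1 `CNC(=O)c1ccncc1Nc1cc(-c2ccc3ccn(C)c3c2)c2nccnc2c1`: 4 ug/mL
- Compound 2 `CN1CCC(NC(=O)c2ccncc2Nc2cc(-c3ccc4ccn(C)c4c3)c3nccnc3c2)CC1`: 246 ug/mL

Compound 2 stands highest of the two, with compound 1 far lower. Compound 3 `CC(=O)N1CCC(NC(=O)c2ccncc2Nc2cc(-c3ccc4ccn(C)c4c3)c3nccnc3c2)CC1` differs from compound 2 by acetyl in place of methyl on an amine nitrogen in a ring. Among the compounds with values here, only one measured step bears on this: a 62-fold higher number from compound 1 to compound 2 (1.79 log units; beyond the scatter), a large step that brought in the 1-methylpiperidin-4-yl group. Within the data shown here, no measured compound carries the acetyl, so this guide is indirect. A large move to a lower number in this assay is expected, though not a full return to compound 1 at 4 ug/mL. The expected step is a 9.8-fold lower number from compound 2 to compound 3 (0.99 log units; beyond the scatter). Compound 3 is estimated at 25 ug/mL, with an expected range of 6 ug/mL to 100 ug/mL.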

Compound 3, solubility: 213 ug/mL
Estimate against measurement, compound 3: 8.5-fold (0.93 log units) below, outside the stated range (above it).
By their numbers in this assay, from the lowest: compound 1; then compounds 3 and 2 (each within the scatter of the next).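

In this assay, acetyl in place of methyl on the amine nitrogen in the ring gives a 1.2-fold lower number from compound 2 to compound 3 (0.06 log units; within the scatter), so this position accepted the change with no step beyond the scatter. The high number therefore does not belong to the 1-methylpiperidin-4-yl group alone: 1-acetylpiperidin-4-yl on the amide-type nitrogen gives a 53-fold higher number from compound 1 to compound 3 (1.73 log units; beyond the scatter). No evidence here accounts for this result.

As far as these compounds go, whether a methylsulfonyl group or a carboxylic acid on that ring nitrogen would read the same remains open. So does whether a simple amine chain in place of the ring would keep the high number.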